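The source may report more compounds than this note shows. Statements on the series, on what has been measured and on what is new or still open speak of the compounds shown alone.

Measured compounds:
Compound 1, `O=C(Nc1ccc(OC(F)(F)F)cc1)NC1CCN(C(=O)C2CCOCC2)CC1`, gives 91 ug/mL in a physicochemical assay for solubility, read by mass spectrometry, in phosphate buffer, with a stated time of 24 h, at pH 7.4; a higher number here means a more soluble compound, a lower number a less soluble compound.
Compound 2, `O=C(Nc1ccc(C(F)(F)F)c(F)c1)NC1CCN(C(=O)C2CCOCC2)CC1`, gives 42 ug/mL in this assay.
Compound 3, `O=C(Nc1ccc(OC(F)(F)F)cc1)NC1CCN(C(=O)C2CCCOC2)CC1`, gives 94 ug/mL in this assay.

Compound 3 differs from compound 1 by oxan-3-yl in place of oxan-4-yl on a carbonyl carbon, and this change made a step of a 1.0-fold higher number from compound 1 to compound 3 (0.01 log units; within the scatter). Compound 2 sits at the lowest of the three numbers, and its gap to compound 1 and to compound 3 is in each case beyond the scatter; the difference between the core of compound 2 and the core of compound 1 is not broken down here.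

Compound 4, `O=C(Nc1ccc(C(F)(F)F)c(F)c1)NC1CCN(C(=O)C2CCCOC2)CC1`, is not yet measured. It differs from compound 2 by oxan-3-yl in place of oxan-4-yl on a carbonyl carbon, the same change in the same place as that from compound 1 to compound 3. In this assay the step is expected to be no change at the digits printed from compound 2 to compound 4 (within the scatter), because the same change gave a 1.0-fold higher number from compound 1 to compound 3 (0.01 log units; within the scatter). That rests on a single measured pair, so the expectation carries the scatter of the method. Compound 4 is therefore estimated at 42 ug/mL, with a likely range from 24 ug/mL to 75 ug/mL.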

Compound 4, solubility: 11 ug/mL
The estimate for compound 4 lay 3.8-fold (0.58 log units) above the measured number; the measured number lies below the stated range.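

In this assay, oxan-3-yl in place of oxan-4-yl on a carbonyl carbon gave a 3.8-fold lower number from compound 2 to compound 4 (0.58 log units; beyond the scatter), beyond the scatter, while the same change gave a 1.0-fold higher number from compound 1 to compound 3 (0.01 log units; within the scatter), within the scatter, so the result on the core of compound 1 did not carry over to the core of compound 2. This shows that, in these two pairs, the outcome of the change depends on the core, but with a single pair on each core it does not show how general that dependence is or how the change would behave on any other core. No measurement shown here gives a reason for the difference between the two steps.

The compounds shown leave open whether the oxan-3-yl change would give a step of either kind on a third core. They also leave open how an amine, a carboxylic acid or a longer alkyl chain in place of oxan-4-yl on the carbonyl carbon would read on these two cores.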